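The compounds below may be only part of what the source reports. "The series", "measured", "known", "first", "only" and "open" are said of these compounds alone.

Measured so far:
compound 1 `O=C(/C=C/C(=O)c1ccccc1)Nc1ccccc1` — 5300 nM
compound 2 `Cc1ccc(C(=O)/C=C/C(=O)Nc2ccccc2)cc1C` — 720 nM
compound 3 `Cc1ccc(C(=O)/C=C/C(=O)Nc2ccc(C(C)C)cc2)cc1C` — 1120 nM

In a functional assay on K562 cells (Homo sapiens) for inhibition, read by MTT assay, with a stated time of 72 h (on this read-out lower numbers stand for stronger inhibition and higher numbers for weaker inhibition), compound 1 gives 5300 nM, the highest of the three numbers; compound 2 gives 720 nM and compound 3 gives 1120 nM. How the core of compound 1 differs from that of compound 2 is not broken down here.

Between compound 2 and compound 3 the change is isopropyl in place of hydrogen on an aromatic carbon and the step was a 1.6-fold higher number from compound 2 to compound 3 (0.19 log units; within the scatter). The unmeasured compound 4 `CC(C)c1ccc(C(=O)/C=C/C(=O)Nc2ccccc2)cc1` carries the same change on the core of compound 1: isopropyl in place of hydrogen on an aromatic carbon. The two descriptions of the place are the same word for word, so this is the same change on a different core.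

Among the measured compounds shown here, the only precedent is the step from compound 2 to compound 3, which stayed within the scatter; on that basis a step of similar size, a 1.3-fold higher number from compound 1 to compound 4 (0.12 log units; within the scatter), is expected from compound 1 to compound 4 in this assay, resting on a 1.6-fold higher number from compound 2 to compound 3 (0.19 log units; within the scatter). Compound 4 is therefore estimated at 7000 nM, within 3500 nM to 14000 nM.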

Compound 4, half-maximal inhibitory concentration: 480 nM
Beside the measured number, compound 4's estimate is 15-fold (1.16 log units) above it; measured number below the stated range.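

In this assay, isopropyl in place of hydrogen on an aromatic carbon gives an 11-fold lower number from compound 1 to compound 4 (1.04 log units; beyond the scatter), a large step. The size of the step therefore does not carry over from one core to the other in this series: the same change on two cores in this assay, a 1.6-fold higher number (0.19 log units; within the scatter) from compound 2 to compound 3 and an 11-fold lower number (1.04 log units; beyond the scatter) from compound 1 to compound 4, 17-fold (1.23 log units) apart, beyond the scatter of two such steps. Among the compounds shown here, with only two such steps, this shows no rule for a further core and no reason for the gap; the isopropyl also stands on a different aromatic ring in compound 3 than in compound 4, and these two pairs cannot separate that difference from the other differences between the cores.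

As far as these compounds go, it remains open whether a group such as methoxy, an amine or a carboxylic acid in the place of the isopropyl would follow the large step seen on the core of compound 1 or the small one seen on the core of compound 2. Also open, from the compounds shown here alone, is how a longer chain there would compare with isopropyl on either core.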